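The source may report more compounds than this note shows. Statements on the series, on what has been measured and on what is new or still open speak of the compounds shown alone.

Of the compounds shown here, two built on one shared core have been measured in an assay for binding affinity to dual specificity mitogen-activated protein kinase kinase 4 (Homo sapiens), read by KINOMEscan, tested at 100 nM; a higher number here means a weaker effect of the compound at the concentration tested, a lower number a stronger effect. Compound 1 `CCCS(=O)(=O)Nc1ccc(F)c(C(=O)c2n[nH]c3ncc(-c4ccccc4Cl)cc23)c1F` gives 9.3% in this assay . Compound 2 `CCCS(=O)(=O)Nc1ccc(F)c(C(=O)c2n[nH]c3ncc(-c4cccc(C(F)(F)F)c4)cc23)c1F` gives 57% in this assay . For the measured compounds named here, compound 2 thus stands highest of the two numbers, and the single step measured so far, a number 47.7 percentage points higher from compound 1 to compound 2 (beyond the scatter), shows how far apart the two lie.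

Compound 3 `CCCS(=O)(=O)Nc1ccc(F)c(C(=O)c2n[nH]c3ncc(-c4ccc(S(N)(=O)=O)cc4C)cc23)c1F` has not yet been measured. It differs from compound 2 in one place: 2-methyl-4-sulfamoylphenyl in place of 3-(trifluoromethyl)phenyl on an aromatic carbon. Going by the values given here, the only measured step that bears on this change is the one at the same aromatic carbon, a number 47.7 percentage points higher from compound 1 to compound 2 (beyond the scatter), and it was large. It shows that exchanging the ring at this position can move the number a long way, but neither group entering in compound 3 has been tried here, so the direction of the coming step is uncertain. The step expected is a number 27 percentage points lower from compound 2 to compound 3 (beyond the scatter), a return toward the lower number, with wide uncertainty. Compound 3 is estimated at 30%, with a range from 5% to 70%.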

Compound 3, a percentage reported as activity, at one concentration (the size of the read-out at that concentration, not a potency): 3.1%
Compound 3: the middle estimate sits 26.9 percentage points above what was measured; the whole stated range lies above it.
By their numbers in this assay, from the lowest: compounds 3 and 1 (each within the scatter of the next); then compound 2.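

In this assay, the high number of compound 2 turns out not to be a fixed outcome for rings at this position: putting 2-methyl-4-sulfamoylphenyl in place of 3-(trifluoromethyl)phenyl gives a number 53.9 percentage points lower from compound 2 to compound 3 (beyond the scatter). The comparison with the earlier low-number compound shows something further, since the same ring in place of 2-chlorophenyl gives a number 6.2 percentage points lower from compound 1 to compound 3 (within the scatter), so these two quite differently substituted rings cannot be told apart in this assay, even though only one of them carries a sulfamoyl group with its hydrogen-bond donor and acceptors. Nothing available explains why the number moves so far between these rings.

The methyl and the sulfamoyl group enter together and the trifluoromethyl group leaves at the same time, so these compounds cannot show which of the changes accounts for the large step, or whether it takes more than one of them. From the compounds shown here alone, it also remains open how the number would respond to a ring at this position bearing an amine or a carboxylic acid in place of the sulfamoyl group.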